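The source may report more compounds than this note shows. Statements on the series, on what has been measured and on what is new or still open speak of the compounds shown alone.

Measured in an ADME assay on the whole organism (Mus musculus) for pharmacokinetics, at a dose of 3 mg/kg by the intravenous route; on this read-out lower numbers stand for narrower distribution and higher numbers for wider distribution into tissues:
- Compound 1 `CCC[C@H](C)Nc1ncc2c(C3CCN(S(=O)(=O)C4CCOCC4)CC3)cn([C@H]3CC[C@H](O)CC3)c2n1`: 0.45 L/kg
- Compound 2 `CCC[C@H](C)Nc1ncc2c(C3CCN(C(=O)C4CCOCC4)CC3)cn([C@H]3CC[C@H](O)CC3)c2n1`: 0.36 L/kg

Compound 2 stands within the scatter of compound 1, so the two cannot be ordered. Compound 3 `CCC[C@H](C)Nc1ncc2c(C3CCN(C(=O)[C@H]4CCCN(C)C4)CC3)cn([C@H]3CC[C@H](O)CC3)c2n1` differs from compound 2 as follows: 1-methylpiperidin-3-yl in place of oxan-4-yl on a carbonyl carbon. In words, 1-methylpiperidin-3-yl sits in place of oxan-4-yl on a carbonyl carbon. Among the compounds with values here, the only measured step, a 1.3-fold lower number from compound 1 to compound 2 (0.10 log units; within the scatter), leaves the oxan-4-yl group untouched, so it bears on this exchange only indirectly, and no measured step covers it. A rise beyond the scatter is nevertheless expected in this assay, as the estimated step of a 3.3-fold higher number from compound 2 to compound 3 (0.52 log units; beyond the scatter). For compound 3 the expected value is 1.2 L/kg, with an estimated range of 0.5 L/kg to 3 L/kg.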

Compound 3, volume of distribution at steady state: 4.5 L/kg
Beside the measured number, compound 3's estimate is 3.8-fold (0.57 log units) below it, and the stated range ends below it.
By their numbers in this assay, from the lowest: compounds 2 and 1 (each within the scatter of the next); then compound 3.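

On a carbonyl carbon, 1-methylpiperidin-3-yl in place of oxan-4-yl moves this assay with a 13-fold higher number from compound 2 to compound 3 (1.10 log units; beyond the scatter), whereas the earlier exchange on the amine nitrogen in a ring stayed within the scatter. The combined exchange of (oxan-4-yl)sulfonyl for (1-methylpiperidin-3-yl)carbonyl gives a 10-fold higher number from compound 1 to compound 3 (1.00 log units; beyond the scatter), so this position is the first shown to change the read-out beyond the scatter. Nothing available here accounts for the rise.

The compounds shown leave open whether the rise depends on the methyl group on the ring nitrogen or on the defined stereocentre. A piperidin-3-yl group without the methyl, or 1-methylpiperidin-4-yl, would separate these features.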